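Carrying one aryl exchange from compound 1 over to compound 3

A few compounds are considered here, and "the series" means these few. Any claim that something is new, unique, unknown or untested is made for them only; others in the source may bear on it.

Compound 1 `COc1ccc(Cl)c(-c2nnc3sc(Cc4c(C)[nH]c5ccc(OC)cc45)nn23)c1` and compound 2 `COc1ccc2[nH]c(C)c(Cc3nn4c(-c5ccoc5C)nnc4s3)c2c1` share a core and differ in one place, (2-methylfuran-3-yl in place of 2-chloro-5-methoxyphenyl on an aromatic carbon). In a functional assay on the whole organism (strain Wistar Albino) for inhibition, with Rattus norvegicus as the target, read by paw edema, with a stated time of 1 h, at a dose of 20 mg/kg (on this read-out lower numbers stand for less inhibition and higher numbers for more inhibition at the one dose given (going by the name of the read-out)), compound 1 gives 11.3% and compound 2 gives 19.7%; the step of a number 8.4 percentage points higher from compound 1 to compound 2 (within the scatter). Compound 3 `COc1ccc(Cl)c(-c2nnc3sc(Cc4c[nH]c5ccccc45)nn23)c1` gives 8.8% in this assay; the difference between the core of compound 3 and the core of compound 1 is not broken down here. Compound 4 `Cc1occc1-c1nnc2sc(Cc3c[nH]c4ccccc34)nn12` has not been measured. It differs from compound 3 by the same change, (2-methylfuran-3-yl in place of 2-chloro-5-methoxyphenyl on an aromatic carbon), at a place described in the same words. For the measured compounds named here, compound 4 is expected to move by a number 8.2 percentage points higher from compound 3 to compound 4 (within the scatter), a step of similar size to the earlier one, because the only precedent a number 8.4 percentage points higher from compound 1 to compound 2 (within the scatter) stayed within the scatter and rests on a single pair. The estimate for compound 4 in this assay is 17%, with a range from 7% to 27%.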

Compound 4, a percentage reported as inhibition, in the whole organism at one dose (the size of the read-out at that dose, not a potency): 16%
For compound 4 the middle estimate is 1 percentage points above the measured one, within the range that was stated.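

In this assay, 2-methylfuran-3-yl in place of 2-chloro-5-methoxyphenyl gives a number 7.2 percentage points higher from compound 3 to compound 4 (within the scatter), and the earlier step on the other core agrees with it: the same change on two cores in this assay, a number 8.4 percentage points higher (within the scatter) from compound 1 to compound 2 and a number 7.2 percentage points higher (within the scatter) from compound 3 to compound 4, 1.2 percentage points apart, within the scatter of two such steps

The step therefore has a similar size on these two cores. Each step alone stays within the scatter, however, and two pairs at one dose and one time show neither a firm gain from this exchange nor how it behaves on any further core.

On these data alone, only these two aromatic groups appear at this place on the five-membered aromatic ring with 3 nitrogen, so the outcome with an amine or a carboxylic acid there remains open. Also open, as far as these compounds go, is whether a larger step appears with either of those groups.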